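From chloro to methyl in a mast cell read-out

The compounds below may be only part of what the source reports. "The series", "measured", "known", "first", "only" and "open" are said of these compounds alone.

In a functional assay (mast cells) for inhibition, with Rattus norvegicus as the target (on this read-out higher numbers stand for an effect only at larger amounts of compound and lower numbers for an effect already at smaller amounts), compound 1 (`CC1CC/C(=N\Nc2ccccc2)c2ncc(CC(=O)O)c(=O)n21`) gives 430000 nM and compound 2 (`CC1CC/C(=N\Nc2cccc(Cl)c2)c2ncc(C(=O)O)c(=O)n21`) gives 311000 nM as its number, so these two lie within the scatter of each other. Compound 3 (`CCOc1ccc(N/N=C2\CC[C@H](C)n3c2ncc(C(=O)O)c3=O)cc1`) gives 19200 nM as its number, which is lower than that of compound 2 by more than the scatter. Compound 2 therefore stands with compound 1 at the high end of the three numbers.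

Compound 4 (`Cc1cccc(N/N=C2\CCC(C)n3c2ncc(C(=O)O)c3=O)c1`) has not yet been measured. It differs from compound 2 in one place: methyl in place of chloro on an aromatic carbon with methyl in place of chloro on an aromatic carbon, which turns 3-chlorophenyl into 3-methylphenyl. Within the data shown here, no measured pair shows this exchange, so its size cannot be read directly from the data. Starting from compound 2 at 311000 nM in this assay no step beyond the scatter is expected. Compound 3 at 19200 nM shows that lower numbers occur among these compounds, so the expected range is left wider on the lower side. The estimate means an expected 1.2-fold lower number from compound 2 to compound 4 (0.09 log units; within the scatter) that stays within the scatter. For compound 4 the estimated value is 250000 nM with a range from 80000 nM to 500000 nM as the expected span.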

Compound 4, half-maximal effective concentration: 72900 nM
Compound 4: middle estimate off by 3.4-fold (0.54 log units), on the high side, and the stated range ends above it.
By their numbers in this assay, from the lowest: compound 3; then compound 4; then compounds 2 and 1 (each within the scatter of the next).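

The exchange of chloro for methyl on an aromatic carbon, meta to a large group, is not silent in this assay: it gives a 4.3-fold lower number from compound 2 to compound 4 (0.63 log units; beyond the scatter), the first size for any single change among these compounds. Both groups count one heavy atom, with no hydrogen-bond donors, no hydrogen-bond acceptors and no net charge, so this position responds to an exchange that leaves all of those counts unchanged. Nothing measured on the two groups or on the compounds bears on what lies behind this step.

From the compounds shown here alone, the step rests on a single pair, so it remains open whether the same exchange would give a step of similar size at another carbon of the ring or on a core carrying other changes. Going by these compounds, it is also open how this position would respond to other groups, such as fluoro, methoxy, an amine or a longer chain like ethyl, and whether any of them would give a lower number than methyl or return to the level of chloro.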